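The compounds below may be only part of what the source reports. "The series", "measured", "known", "first", "only" and "open" are said of these compounds alone.

Measured in a functional assay on A549 cells (Homo sapiens) for antiproliferative activity, read by sulforhodamine B assay, with a stated time of 3 days; a higher number here means a weaker inhibitor of growth, a lower number a stronger inhibitor of growth:
- Compound 1 `O=C(c1cccc(Nc2ncc(F)c(Nc3ccc(F)cc3)n2)c1)N1CCCCC1`: 13200 nM
- Compound 2 `O=C(Nc1cc(Cl)cc(Cl)c1)c1cccc(Nc2ncc(F)c(Nc3ccc(F)cc3)n2)c1`: 17500 nM

Within the data shown here, compound 2 stands level, within the scatter, with the only other compound measured. Among the measured compounds shown here, the single measured step is a 1.3-fold higher number from compound 1 to compound 2 (0.12 log units; within the scatter), with (3,5-dichlorophenyl)amino in place of piperidin-1-yl on a carbonyl carbon. Compound 3 `Cn1ccnc1NC(=O)c1cccc(Nc2ncc(F)c(Nc3ccc(F)cc3)n2)c1` is reached from compound 2 by a further change at that amide: 1-methyl-1H-imidazol-2-yl in place of 3,5-dichlorophenyl on an amide-type nitrogen. In words, 1-methyl-1H-imidazol-2-yl takes the place of 3,5-dichlorophenyl on an amide-type nitrogen. For the measured compounds named here, no measured compound carries this new ring, so the guide is thin. Resting on a 1.3-fold higher number from compound 1 to compound 2 (0.12 log units; within the scatter), no step beyond the scatter is expected in this assay, and no direction is favoured. The expected change is a 1.3-fold lower number from compound 2 to compound 3 (0.10 log units; within the scatter). For compound 3 the estimated value is 14000 nM, with an expected range of 5000 nM to 40000 nM.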

Compound 3, concentration for 50% growth inhibition: 10100 nM
Beside the measured number, compound 3's estimate is 1.4-fold (0.14 log units) above it, within the range that was stated.
By their numbers in this assay, from the lowest: compounds 3, 1 and 2 (each within the scatter of the next).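

In this assay, a five-membered aromatic ring with 2 hetero atoms on the amide-type nitrogen gives a number level with that of the six-membered carbon-only ring (a 1.7-fold lower number from compound 2 to compound 3 (0.24 log units; within the scatter)), so this position has now carried two different aromatic rings without a step beyond the scatter. The same holds against piperidin-1-yl on the carbonyl carbon (a 1.3-fold lower number from compound 1 to compound 3 (0.12 log units; within the scatter)), which leaves all three compounds level, even though 1-methyl-1H-imidazol-2-yl brings 2 hydrogen-bond acceptors where 3,5-dichlorophenyl has none. Nothing available explains why the numbers stay level.

From the compounds shown here alone, it remains open whether any change at this amide can move the number beyond the scatter, for instance a piperazine ring or a carboxylic acid. Going by these compounds, it is equally open whether the two fluorines on the shared core matter more than this position does.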